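The source may report more compounds than this note shows. Statements on the series, on what has been measured and on what is new or still open speak of the compounds shown alone.

Of the compounds shown here, three of a shared core have been measured in a functional assay on A498 cells (Homo sapiens) for inhibition; on this read-out higher numbers stand for weaker inhibition of growth and lower numbers for stronger inhibition of growth. Compound 1 `COc1cc(/C=C/C(=O)c2cccc(-n3cc(-c4ccccc4)[nH]c3=O)c2)ccc1O` gives 1680 nM, and compound 2 `O=C(/C=C/c1cccc(O)c1)c1cccc(-n2cc(-c3ccccc3)[nH]c2=O)c1` gives 14300 nM. Among the compounds with values here, the one measured step, an 8.5-fold higher number from compound 1 to compound 2 (0.93 log units; beyond the scatter), concerns the hydroxy-methoxy-bearing ring at the end of the double-bonded chain. Compound 3 `COc1cc(/C=C/C(=O)c2cccc(-n3cc(-c4ccccc4)[nH]c3=O)c2)cc(OC)c1OC` gives 2650 nM, which is the second highest of the three numbers: it sits within the scatter of compound 1 and beyond the scatter of compound 2.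

Compound 4 `COc1cc(/C=C/C(=O)c2cccc(-n3cc(-c4cc(OC)c(OC)c(OC)c4)[nH]c3=O)c2)cc(OC)c1OC` differs from compound 3 at the other end of the molecule, on the five-membered ring with two nitrogens: 3,4,5-trimethoxyphenyl in place of phenyl on an aromatic carbon. Within the data shown here, the one measured step, from compound 1 to compound 2, touches a different part of the structure and so gives no direct guide here. With nothing measured for this change, the step in this assay from compound 3 to compound 4 is expected to stay within the scatter, and could fall in either direction. The expected step is a 1.1-fold lower number from compound 3 to compound 4 (0.03 log units; within the scatter). Compound 4 is therefore estimated at 2500 nM, with a range from 800 nM to 8000 nM.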

Compound 4, concentration for 50% growth inhibition: 20300 nM
Compound 4: middle estimate off by 8.1-fold (0.91 log units), on the low side; measured number outside the range, above it.
By their numbers in this assay, from the lowest: compounds 1 and 3 (each within the scatter of the next); then compounds 2 and 4 (each within the scatter of the next).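

Until now, only the ring at the end of the double-bonded chain had changed. Compound 4 shows that the aromatic carbon of the five-membered aromatic ring with 2 nitrogen matters as well: in this assay, putting 3,4,5-trimethoxyphenyl in place of phenyl gives a 7.7-fold higher number from compound 3 to compound 4 (0.88 log units; beyond the scatter), meaning weaker inhibition of growth. No available measurement accounts for this step.

Going by these compounds, the swap brings in all three methoxy groups at once, so the effect of each one alone remains unknown, as does the outcome of the same swap on the core of compound 1. Also open, on these data alone, is how this position would respond to a different group on the phenyl ring, such as an amine or a carboxylic acid.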